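The compounds below may be only part of what the source reports. "The series", "measured", "known", "first", "only" and "open" are said of these compounds alone.

compound 1 `O=C(NCc1ccccc1)c1cc(Oc2cccc(NC(=S)Nc3ccc(Cl)cc3)c2)ccn1`: 16500 nM
compound 2 `CCNC(=O)c1cc(Oc2cccc(NC(=S)Nc3cccc(C(F)(F)F)c3)c2)ccn1`: 19400 nM
compound 3 `O=C(NC1CC1)c1cc(Oc2cccc(NC(=S)Nc3cccc(C(F)(F)F)c3)c2)ccn1`: 20200 nM

In a functional assay on HCT-116 cells (Homo sapiens) for cytotoxicity, read by MTT assay, with a stated time of 48 h (on this read-out higher numbers stand for weaker inhibition and lower numbers for stronger inhibition), compound 3 gives the highest of these three numbers, yet its gaps to compound 2 and to compound 1 both lie within the scatter, so no real order among the three can be read from them. Compound 4 `O=C(NCc1ccccc1)c1cc(Oc2cccc(NC(=S)Nc3cccc(C(F)(F)F)c3)c2)ccn1` differs from compound 3 by benzyl in place of cyclopropyl on an amide-type nitrogen. Going by the values given here, the only measured step that bears on this place is a 1.0-fold higher number from compound 2 to compound 3 (0.02 log units; within the scatter), an exchange of one small group for another on the same amide nitrogen that left the number unchanged. Compound 1 already carries the benzyl group, and its value sits close to that of compound 3. The change to compound 4 is therefore expected to give a 1.2-fold lower number from compound 3 to compound 4 (0.07 log units; within the scatter), nothing beyond the scatter. Compound 4 is estimated at 17000 nM, with a range from 9000 nM to 34000 nM.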

Compound 4, half-maximal inhibitory concentration: 7500 nM
Beside the measured number, compound 4's estimate is 2.3-fold (0.36 log units) above it; measured number outside the range, below it.
By their numbers in this assay, from the lowest: compound 4; then compounds 1, 2 and 3 (each within the scatter of the next).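

In this assay, the group on this amide-type nitrogen does matter: benzyl in place of cyclopropyl gives a step beyond the scatter (a 2.7-fold lower number from compound 3 to compound 4 (0.43 log units; beyond the scatter)), and the step from the ethyl amide is similar (a 2.6-fold lower number from compound 2 to compound 4 (0.41 log units; beyond the scatter)), although ethyl and cyclopropyl themselves gave no readable difference. With benzyl held fixed, 3-(trifluoromethyl)phenyl in place of 4-chlorophenyl also gives a modest step (a 2.2-fold lower number from compound 1 to compound 4 (0.34 log units; beyond the scatter)). Nothing available explains these steps. Going by these compounds, how a phenyl or 2-phenylethyl group on that amide-type nitrogen would compare with benzyl remains open.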